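Swapping Isopropoxy for Dimethylamino on a Carbonyl Carbon

The source may report more compounds than this note shows. Statements on the series, on what has been measured and on what is new or still open speak of the compounds shown alone.

Of the compounds shown here, three sharing one core have been measured so far. In an ADME assay on HeLa cells (Homo sapiens) for cytotoxicity, read by crystal violet staining, with a stated time of 72 h (a higher number here means that more compound is tolerated, a lower number that less compound is tolerated), compound 3 (`Cc1cc(-c2noc(C(F)(F)F)n2)cc(C)c1OCCCc1cc(C(=O)OC(C)C)no1`) gives 17900 nM as its half-maximal cytotoxic concentration. In this assay compound 1 (`CCOC(=O)c1cc(CCCOc2ccc(-c3noc(C(F)(F)F)n3)cc2C)on1`) gives 35100 nM as its result, and these two numbers lie within the usual scatter of each other, so they cannot be told apart. Compound 2 (`CCOC(=O)c1cc(CCCOc2c(OC)cc(-c3noc(C(F)(F)F)n3)cc2[N+](=O)[O-])on1`) is reported only as a limit, > 100000 nM and not as a number.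

The next compound, compound 4 (`Cc1cc(-c2noc(C(F)(F)F)n2)cc(C)c1OCCCc1cc(C(=O)N(C)C)no1`), keeps the rest of compound 3 and changes a single group: dimethylamino in place of isopropoxy on a carbonyl carbon. Cut one bond further out, the same difference reads isopropoxycarbonyl to dimethylcarbamoyl.

Among the compounds with values here, no measured pair of compounds shows this kind of change, so any forecast here is loose. The likeliest outcome is a modest shift toward more compound being tolerated in this assay and not a dramatic one. The expected size of the move is a 2.2-fold higher number from compound 3 to compound 4 (0.35 log units; beyond the scatter) and it could still prove hard to separate from the scatter. For compound 4 the estimated value is 40000 nM with a range from 12000 nM to 100000 nM as the expected span.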

Compound 4, half-maximal cytotoxic concentration: 13200 nM
Beside the measured number, compound 4's estimate is 3.0-fold (0.48 log units) above it; the range from low to high includes it.
By their numbers in this assay, from the lowest: compounds 4, 3 and 1 (each within the scatter of the next, the first and the last beyond it). At a limit, above all of these: compound 2.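

Within the data shown here, the swap of isopropoxy for dimethylamino gives the first comparison here between compounds that differ in one place, and in this assay it reads a 1.4-fold lower number from compound 3 to compound 4 (0.13 log units; within the scatter). This step is too small to count as a real change, so on this carbonyl carbon, isopropoxycarbonyl and dimethylcarbamoyl cannot be told apart by how much compound the cells tolerate, at least on the background that compound 3 and compound 4 share. This is a single pair, so it sets no rule for other versions of the shared core, and nothing shown here offers an explanation for the result.

Still open, on these data alone, is whether any group on this carbonyl carbon can move the number beyond the scatter, for instance a free carboxylic acid, a simple primary amide, or an amine carrying longer chains than the methyl groups of dimethylamino. Also open, as far as these compounds go, is whether the same swap would behave alike on the other substitution patterns of the shared core, since compound 1 and compound 2 differ from compound 4 in more than one place and so offer no clean comparison.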